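A few compounds are considered here, and "the series" means these few. Any claim that something is new, unique, unknown or untested is made for them only; others in the source may bear on it.

Of the compounds shown here, three sharing one core have numbers so far in a functional assay on MDA-MB-231 cells (Homo sapiens) for antiproliferative activity, read by MTT assay, with a stated time of 72 h; a higher number here means a weaker inhibitor, a lower number a stronger inhibitor: compound 1 `CC(=O)O[C@H]1CC[C@]2(C)[C@H](CC[C@@](C)(O)[C@H]2CC[C@@H]2C(C)=CC[C@H]3[C@H](CC[C@]3(C)O)C2(C)C)OC1(C)C` (38000 nM), compound 2 `CC1=CC[C@H]2[C@H](CC[C@]2(C)O)C(C)(C)[C@@H]1CC[C@H]1[C@]2(C)CC[C@H](OC(=O)CCC(=O)O)C(C)(C)O[C@H]2CC[C@@]1(C)O` (27900 nM) and compound 3 `CC1=CC[C@H]2[C@H](CC[C@]2(C)O)C(C)(C)[C@@H]1CC[C@H]1[C@]2(C)CC[C@H](OC(=O)c3ccccc3)C(C)(C)O[C@H]2CC[C@@]1(C)O` (16100 nM). Compound 3 is set apart on one side only: a 2.4-fold lower number from compound 1 to compound 3 (0.37 log units; beyond the scatter) is modest but beyond the scatter, whereas a 1.7-fold lower number from compound 2 to compound 3 (0.24 log units; within the scatter) lies within it. Compound 4 `CC1=CC[C@H]2[C@H](CC[C@]2(C)O)C(C)(C)[C@@H]1CC[C@H]1[C@]2(C)CC[C@H](OC(=O)c3ccncc3)C(C)(C)O[C@H]2CC[C@@]1(C)O` differs from compound 3 in one group, with pyridin-4-yl in place of phenyl on a carbonyl carbon. Going by the values given here, the steps that bear on this swap were also made on that carbonyl carbon, and both were small: a 2.4-fold lower number from compound 1 to compound 3 (0.37 log units; beyond the scatter) and a 1.7-fold lower number from compound 2 to compound 3 (0.24 log units; within the scatter) each brought in the phenyl itself. Among the compounds with values here, no measured compound has an aromatic ring with a hetero atom, so the data fix no direction. No step beyond the scatter is therefore expected in this assay, and the estimate is a 1.2-fold higher number from compound 3 to compound 4 (0.07 log units; within the scatter) for this swap. Compound 4 is expected at 19000 nM (estimated range 8500 nM to 38000 nM).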

Compound 4, half-maximal inhibitory concentration: 18000 nM
Compound 4: middle estimate off by 1.1-fold (0.02 log units), on the high side; low and high end bracket the measured number.
By their numbers in this assay, from the lowest: compounds 3, 4, 2 and 1 (each within the scatter of the next, the first and the last beyond it).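

In this assay the carbonyl carbon can carry an aromatic ring with a hetero atom: pyridin-4-yl in place of phenyl adds one hydrogen-bond acceptor and gives a 1.1-fold higher number from compound 3 to compound 4 (0.05 log units; within the scatter), so the two compounds cannot be told apart here. Compared with the other two groups, compound 4 behaves as compound 3 does: a 1.6-fold lower number from compound 2 to compound 4 (0.19 log units; within the scatter) stays within the scatter, while a 2.1-fold lower number from compound 1 to compound 4 (0.32 log units; beyond the scatter) is modest but beyond it, which separates both aromatic rings from the methyl of compound 1 but not from the 2-carboxyethyl of compound 2. Nothing measured here speaks to the reason for this result.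

From the compounds shown here alone, whether a naphthyl ring or a chain bearing an amine on this carbonyl carbon would shift the number further remains open. The rest of the shared core is the same throughout, so these compounds say nothing about changes elsewhere.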